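Working notes on a cytotoxicity series on lung cells

The compounds below may be only part of what the source reports. "The series", "measured", "known", "first", "only" and "open" are said of these compounds alone.

Measured so far:
compound 1 `COc1cccc(/C=C2\CCC/C(=C\c3ccc(O)c(Cl)c3)C2=O)c1OC` — > 20000 nM
compound 2 `COc1ccc(/C=C2\CCC/C(=C\c3ccccc3Br)C2=O)cc1OC` — > 20000 nM

In a functional assay on A549 cells (Homo sapiens) for cytotoxicity, read by MTT assay, with a stated time of 72 h (on this read-out lower numbers stand for stronger inhibition and higher numbers for weaker inhibition), compound 2 gives > 20000 nM, which is a limit of the assay and not a number. Compound 1 likewise gives only a limit in this assay, > 20000 nM. Both values therefore sit at the same point, (the limit of > 20000 nM in this assay, at which 2 of the 2 values shown sit), and no ordering between compound 1 and compound 2 can be read from them. Going by the values given here, no single-point step between measured compounds is available in this set.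

Compound 3 `COc1cc(/C=C2\CCC/C(=C\c3ccc(OC)c(OC)c3)C2=O)ccc1O` is the next compound to be run in this assay. Relative to compound 2 the change is 4-hydroxy-3-methoxyphenyl in place of 2-bromophenyl on a double-bonded chain carbon bound to a double-bonded ring carbon. Among the compounds with values here, with both measured values resting at a limit, there is no measured step on which to base the size of this change. The expected outcome is a step toward stronger inhibition from compound 2 to compound 3 of an at least 1.6-fold lower number from compound 2 to compound 3 (0.22 log units; that floor lies within the scatter), carrying a large uncertainty. Compound 3 is therefore estimated at 12000 nM in this assay, within a range of 3000 nM to 40000 nM, with a real chance that only a limit is again reported.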

Compound 3, half-maximal inhibitory concentration: 10300 nM
Beside the measured number, compound 3's estimate is 1.2-fold (0.07 log units) above it; the measured number falls inside the stated range.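

Going by these compounds alone, compound 3 (10300 nM) is the only compound in this assay with a value that is not a limit, which gives the series its first reading on the scale. From the compounds shown here alone, on a double-bonded chain carbon bound to a double-bonded ring carbon, placing 4-hydroxy-3-methoxyphenyl where 2-bromophenyl stood gives an at least 1.9-fold lower number from compound 2 to compound 3 (0.28 log units; that floor lies within the scatter) and so shows that the change can bring a measurable number, although this floor does not establish a real gain and the true size of the step stays unknown. Compound 1 and compound 2 both remain limits of the assay, so neither provides a second number for comparison: the limit of > 20000 nM in this assay, at which 2 of the 3 values shown sit.

Within the data shown here, the single step cannot separate the contribution of the hydroxy group from that of the methoxy group or from the departure of the bromine, and the other pairing, compound 1 with compound 3, cannot be read as a step. Also open, going by these compounds, is how an amine or a carboxylic acid would read at this same place, and whether any group there brings the number clearly beyond the scatter.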